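From 3-methylphenyl to pyridin-2-yl: working notes

A few compounds are considered here, and "the series" means these few. Any claim that something is new, unique, unknown or untested is made for them only; others in the source may bear on it.

In a functional assay on MCF7 cells (Homo sapiens) for cytotoxicity, read by ELISA, with a stated time of 4 days (a lower number here means a stronger inhibitor, a higher number a weaker inhibitor), compound 1 (`Clc1ccc(-c2cc(-c3ccco3)cc(-c3ccc(Cl)s3)n2)cc1`) gives 1520 nM and compound 2 (`Cc1cccc(-c2cc(-c3ccoc3)cc(-c3ccc(Cl)s3)n2)c1`) gives 3990 nM as the higher of the two numbers, a gap beyond the scatter. Compound 3 (`Clc1ccc(-c2cc(-c3ccoc3)cc(-c3ccccn3)n2)s1`) carries pyridin-2-yl in place of 3-methylphenyl on an aromatic carbon. Within the data shown here, no measured step for this change is available, so the expectation rests on these two values alone. No step beyond the scatter is expected in this assay (estimated as a 1.3-fold lower number from compound 2 to compound 3 (0.12 log units; within the scatter)). For compound 3 the estimated value is 3000 nM (expected range 1000 nM to 9000 nM).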

Compound 3, half-maximal inhibitory concentration: 3360 nM
For compound 3 the middle estimate is 1.1-fold (0.05 log units) below the measured one; the measured number falls inside the stated range.
By their numbers in this assay, from the lowest: compound 1; then compounds 3 and 2 (each within the scatter of the next).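

In this assay pyridin-2-yl in place of 3-methylphenyl, on the aromatic carbon next to the ring nitrogen, gives a 1.2-fold lower number from compound 2 to compound 3 (0.07 log units; within the scatter) and the two compounds read alike. At this position, then, a ring nitrogen and one hydrogen-bond acceptor, with one heavy atom fewer, come with no step beyond the scatter. No supporting data bear on why the two read alike.

Still open, going by these compounds, is how a non-aromatic group at this position, such as a morpholine or a primary amine, would read, and whether the same exchange holds with furan-2-yl in place of furan-3-yl.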